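An Ethyl Ester Replaced by a Carbonate-Bearing Ester

This account rests on a few compounds, and the source may have more. Where it says the series, first, only, none or still open, it means among the compounds named here.

Compound 1 `CCOC(=O)C1=C(S[C@@H]2CN[C@H](C(=O)Nc3cccc(C(=O)O)c3)C2)[C@H](C)[C@@H]2[C@@H]([C@@H](C)O)C(=O)N12` is the starting point. In an ADME assay for metabolic stability, read by LC-MS, with a stated time of 3 h, at pH 6.5, tested at 50 uM (a lower number here means that less of the compound is left, a higher number that more of the compound is left), compound 1 gives > 95%, which is a limit of the assay rather than a number. Compound 2 `COC(=O)C1=C(S[C@@H]2CN[C@H](C(=O)Nc3cccc(C(=O)OC)c3)C2)[C@H](C)[C@@H]2[C@@H]([C@@H](C)O)C(=O)N12` gives > 95%, again a limit. Compound 3 `CCOC(=O)C1=C(S[C@@H]2CN[C@H](C(=O)Nc3cccc(C(=O)OCC)c3)C2)[C@H](C)[C@@H]2[C@@H]([C@@H](C)O)C(=O)N12` gives > 95%, also a limit. All three values fall at the limit of > 95% in this assay, at which 3 of the 3 values shown sit, so compound 1 cannot be placed higher or lower than the others on these numbers; it stands only at a limit.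

The step toward compound 4 `C[C@@H](O)[C@H]1C(=O)N2C(C(=O)OCOC(=O)OC3CCCCC3)=C(S[C@@H]3CN[C@H](C(=O)Nc4cccc(C(=O)O)c4)C3)[C@H](C)[C@H]12` is (cyclohexyloxycarbonyl)oxy in place of methyl on a saturated chain carbon bound to an oxygen next to a carbonyl group. For the measured compounds named here, of the measured steps, only the one from compound 1 to compound 3 touches the oxygen next to a carbonyl group, and it reads a step that the two limits leave unreadable from compound 1 to compound 3, so it gives no size to carry over. The change in compound 4 is larger than any measured one, and with every measured value at the limit the measured steps cannot tell whether this assay will move beyond the scatter, or in which direction. The estimate for compound 4 is therefore wide: an expected 70%, with a range from 30% to 95%. Expressed as a step, this corresponds to an expected a number at least 25 percentage points lower from compound 1 to compound 4 (beyond the scatter).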

Compound 4, percent of the compound remaining: > 95%
Compound 4: no number, only a limit; the forecaster's own chance of this, stated with the estimate: 35%; middle value at least 25 percentage points from the limit.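

In this assay compound 4 gives > 95%, which is a limit of the assay and not a number. For the compounds shown here, no step between compound 1 and compound 4 can be read, since both stand at the same limit: the limit of > 95% in this assay, at which 4 of the 4 values shown sit. The compounds shown leave open whether compound 4 and compound 1 differ at all in the percent remaining, and how the four compounds would rank.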